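Shortening the acid chain in a platelet inhibitor series

The source may hold more compounds than are shown below. What is called first, only, known or untested is meant among the compounds shown, and "the series" means these compounds.

Measured so far:
compound 1, `O=C(O)CN1Cc2ccc(NC(=O)CCCC3CCNCC3)cc2C1=O`, 66000 nM
compound 2, `O=C(O)CCN1Cc2ccc(NC(=O)c3ccc(C4CCNCC4)cc3)cc2C1=O`, 9600 nM
compound 3, `O=C(O)CCN1Cc2ccc(NC(=O)c3ccc(N4CCNCC4)cc3)cc2C1=O`, 540 nM

All three compounds were tested in a functional assay on a cell-free system (Platelet, plasma, Homo sapiens) for inhibition; on this read-out higher numbers stand for weaker inhibition and lower numbers for stronger inhibition. Compound 2 holds the second highest number of the three: compound 1 sits at a higher number and compound 3 at a lower one. Among the measured compounds shown here, the only single-point change among the measured compounds is the one between compound 2 and compound 3, which gave an 18-fold lower number from compound 2 to compound 3 (1.25 log units; beyond the scatter).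

Compound 4, `O=C(O)CN1Cc2ccc(NC(=O)c3ccc(C4CCNCC4)cc3)cc2C1=O`, has not yet been measured. It differs from compound 2 in one place: carboxy in place of carboxymethyl on a saturated chain carbon bound to an amide-type nitrogen in a ring.

For the measured compounds named here, no measured step speaks to this change. The step from compound 2 to compound 3 concerns a different part of the molecule. Compound 1 carries the shorter acid chain, but it also differs from compound 2 in the group between the amide and the basic ring, so its value alone cannot be assigned to either change. With nothing to anchor the direction, the expectation for compound 4 is a number close to that of compound 2, with a wide range on both sides: a 1.6-fold higher number from compound 2 to compound 4 (0.19 log units; within the scatter). Compound 4 is therefore estimated at 15000 nM, between 4000 nM and 60000 nM.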

Compound 4, half-maximal inhibitory concentration: 24000 nM
Compound 4: the middle estimate sits 1.6-fold (0.20 log units) below what was measured; measured number inside the range.
By their numbers in this assay, from the lowest: compound 3; then compound 2; then compound 4; then compound 1.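

In this assay, cutting the acid chain from 2-carboxyethyl to carboxymethyl gives a 2.5-fold higher number from compound 2 to compound 4 (0.40 log units; beyond the scatter), so the shorter chain goes with weaker inhibition in this one matched pair. Among the compounds shown here, this is the first direct reading of chain length at this position, on a saturated chain carbon bound to an amide-type nitrogen in a ring, and it shows that the position responds to a change of a single carbon, though only modestly: the step is smaller than an 18-fold lower number from compound 2 to compound 3 (1.25 log units; beyond the scatter), which comes from the change at the other end of the molecule. No measured evidence here accounts for the size or direction of the shortening step.

As far as these compounds go, two points stay open: whether a longer chain such as 3-carboxypropyl would continue the trend or reverse it, and whether a group other than a carboxylic acid, such as a tetrazole or a methyl ester, could take the place of the acid at the end of the chain. It is equally unknown whether carboxymethyl would cost a similar amount when paired with the piperazin-1-yl group of compound 3.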